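From Compound 2 to Compound 3: an Untested Aryl Swap

This account rests on a few compounds, and the source may have more. Where it says the series, first, only, none or still open, it means among the compounds named here.

In an assay for inhibition of alkaline phosphatase, tissue-nonspecific isozyme (Homo sapiens), read by spectrophotometry, with stated times of 10 min and 20 min (on this read-out lower numbers stand for stronger inhibition and higher numbers for weaker inhibition), compound 1 `O=C1/C(=C/c2ccccc2)NS(=O)(=O)c2ccccc21` gives 660 nM, and compound 2 `O=C1/C(=C/c2ccc(Cl)cc2)NS(=O)(=O)c2ccccc21` gives 250 nM. Among the measured compounds shown here, the only measured step, a 2.6-fold lower number from compound 1 to compound 2 (0.42 log units; beyond the scatter), leaves compound 2 at the lowest of the two numbers, with compound 1 as its nearest neighbour. Compound 3 `Cc1ccccc1/C=C1\NS(=O)(=O)c2ccccc2C1=O` has not yet been measured. It differs from compound 2 by 2-methylphenyl in place of 4-chlorophenyl on a double-bonded chain carbon bound to a double-bonded ring carbon. The step from compound 1 to compound 2 bears only indirectly on this change: it shows that a group on that aromatic ring can move the number, but nothing measured speaks to a methyl group or to the placement given in the name 2-methylphenyl. Compound 3 is therefore expected to give about 500 nM, within a range from 200 nM to 1500 nM. The expected step is a 2.0-fold higher number from compound 2 to compound 3 (0.30 log units; within the scatter), a modest rise whose direction the data leave uncertain.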

Compound 3, half-maximal inhibitory concentration: 2360 nM
Compound 3: the middle estimate sits 4.7-fold (0.67 log units) below what was measured; measured number outside the range, above it.
By their numbers in this assay, from the lowest: compound 2; then compound 1; then compound 3.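

In this assay the swap on the double-bonded chain carbon bound to a double-bonded ring carbon is costly, with a 9.4-fold higher number from compound 2 to compound 3 (0.97 log units; beyond the scatter) when 2-methylphenyl stands in place of 4-chlorophenyl. The earlier compounds shown here showed only a fall in the number on adding a group to the aromatic ring, whereas adding a methyl group to that ring moves it the other way, with a 3.6-fold higher number from compound 1 to compound 3 (0.55 log units; beyond the scatter) on that change, so a group on this ring does not lower the number as such. The data at hand offer no explanation for this rise.

On these data alone, whether the rise belongs to the methyl group itself or to its placement in 2-methylphenyl stays open, as the two groups compared differ in both respects. As far as these compounds go, what a methoxy group or an amine on that aromatic ring would do also remains open.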